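Trifluoromethyl for Nitro on a Triazene Core

The source may report more compounds than this note shows. Statements on the series, on what has been measured and on what is new or still open speak of the compounds shown alone.

The account concerns compound 1 `O=[N+]([O-])c1cccc(/N=N/N2CCCC2)c1`, whose reading in an ADME assay on MDBK cells (Bos taurus) for cytotoxicity, read by MTT assay, with a stated time of 96 h (on this read-out lower numbers stand for higher toxicity in this test and higher numbers for lower toxicity in this test), is not a number but a limit of the assay: compound 1 gives > 100000 nM. Compound 1 therefore stands at the edge of what this assay reports, and it is not alone there, since (the limit of > 100000 nM in this assay, at which 2 of the 3 values shown sit). Compound 3 `O=[N+]([O-])c1cccc(/N=N/Nc2cccc([N+](=O)[O-])c2)c1` is the other compound at that edge, and in this assay compound 3 likewise gives only the limit > 100000 nM. Among the compounds with values here, compound 2 `Cc1c(/N=N/c2cccc(C(F)(F)F)c2)ccc(NC[C@@H]2CCCN3CCCC[C@H]23)c1C`, built on a different core, is the one compound with a number: in this assay compound 2 gives 52000 nM.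

The step under study leads from compound 1 to compound 4 `FC(F)(F)c1cccc(/N=N/N2CCCC2)c1`. The change is trifluoromethyl in place of nitro on an aromatic carbon, on the same core and with the rest of compound 1 kept as it is.

Within the data shown here, no measured pair in this set differs in one place only. Among the measured compounds shown here, the size of this step thus has no direct precedent. With the two limits that frame compound 1 in view, he expects no step beyond the scatter in this assay, and estimates that the step from compound 1 to compound 4 is an at least 1.1-fold lower number from compound 1 to compound 4 (0.04 log units; that floor lies within the scatter). For compound 4 he estimates 90000 nM, within 30000 nM to 250000 nM.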

Compound 4, half-maximal cytotoxic concentration: > 100000 nM
Compound 4: no number, only a limit (the forecaster's own chance of this, stated with the estimate: 55%); middle value at least 1.1-fold (0.04 log units) away from the limit.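

In this assay compound 4 gives > 100000 nM as a limit and not a number. Compound 1 also gives only a limit, so no step can be read between compound 1 and compound 4: the limit of > 100000 nM in this assay, at which 3 of the 4 values shown sit. The compounds shown leave open how far trifluoromethyl in place of nitro moves the half-maximal cytotoxic concentration on the shared core.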